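A few compounds are considered here, and "the series" means these few. Any claim that something is new, unique, unknown or untested is made for them only; others in the source may bear on it.

Compound 1 `COc1nc(C2=NOC(C)(C)C(c3ccccc3)N2)ccc1-n1cnc(C)c1` and compound 2 `COc1nc(C2=NOC(C)(C)C(c3ccc(Cl)cc3)N2)ccc1-n1cnc(C)c1` share a core, and compound 2 differs from compound 1 only by chloro in place of hydrogen on an aromatic carbon. In an ADME assay on cells (Hepatocyte, Homo sapiens) for pharmacokinetics (a higher number here means faster removal of the compound, a lower number slower removal), compound 1 gives 5 mL/min/kg, and compound 2 gives 15 mL/min/kg; the step of a 3.0-fold higher number from compound 1 to compound 2 (0.48 log units; beyond the scatter). Compound 3 `COc1nc(C2=NOC(C)C(c3cccc(Cl)c3)N2)ccc1-n1cnc(C)c1` has a different core; how it differs from compound 1 is not broken down here. In this assay compound 3 gives 19 mL/min/kg, which is within the scatter of the number for compound 2. Compound 4 `COc1nc(C2=NOC(C)C(c3ccc(Cl)c(Cl)c3)N2)ccc1-n1cnc(C)c1` differs from compound 3 by chloro in place of hydrogen on an aromatic carbon, the same kind of change as from compound 1 to compound 2, though here the new group sits ortho to a chloro group (1 heavy atom). Resting on the step of a 3.0-fold higher number from compound 1 to compound 2 (0.48 log units; beyond the scatter) in the other core, a step of similar size, a 2.1-fold higher number from compound 3 to compound 4 (0.32 log units; beyond the scatter), is expected, so the clearance of compound 4 is estimated at 40 mL/min/kg, likely between 20 mL/min/kg and 80 mL/min/kg.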

Compound 4, clearance: 20 mL/min/kg
Beside the measured number, compound 4's estimate is 2.0-fold (0.30 log units) above it, and the stated range covers the measured number.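

In this assay, chloro in place of hydrogen on an aromatic carbon gives a 1.1-fold higher number from compound 3 to compound 4 (0.02 log units; within the scatter). In this series, the size of the step did not carry over from one core to the other: the same change on two cores in this assay, a 3.0-fold higher number (0.48 log units; beyond the scatter) from compound 1 to compound 2 and a 1.1-fold higher number (0.02 log units; within the scatter) from compound 3 to compound 4, 2.9-fold (0.45 log units) apart, beyond the scatter of two such steps. This does not show whether the core alone sets the size of the step, as the new chloro group in compound 4 also sits ortho to a chloro group, a feature that the step from compound 1 to compound 2 lacks.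

The compounds shown leave open what the step from 3-chlorophenyl to 3,4-dichlorophenyl would give on the core of compound 1. They also leave open how a fluoro, methoxy or nitrile group at that place would read in this assay.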